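Removing the 4-fluorobenzyl arm: notes on compound 4

The compounds below may be only part of what the source reports. "The series", "measured", "known", "first", "only" and "open" are said of these compounds alone.

Compound 3 `COc1cc(Oc2cccc(Nc3ccccc3)c2)cc(OC)c1CNCc1ccc(F)cc1` gives 4220 nM in a functional assay on HCT-116 cells (Homo sapiens) for inhibition, read by MTT assay, with a stated time of 72 h (on this read-out higher numbers stand for weaker inhibition and lower numbers for stronger inhibition), the highest of the three numbers, though its gaps to compound 2 `COc1cc(Oc2cccc(Nc3ccccc3)c2)cc(OC)c1CNCc1ccccc1` with 4070 nM and to compound 1 `COc1ccc(CNCc2c(OC)cc(Oc3cccc(Nc4ccccc4)c3)cc2OC)cc1` with 2620 nM both lie within the scatter. Compound 4 `CNCc1c(OC)cc(Oc2cccc(Nc3ccccc3)c2)cc1OC` differs from compound 3 by hydrogen in place of 4-fluorophenyl on a saturated chain carbon bound to an amine nitrogen. The measured steps only vary the substituent on that departing ring: a 1.6-fold higher number from compound 1 to compound 2 (0.19 log units; within the scatter), a 1.6-fold higher number from compound 1 to compound 3 (0.21 log units; within the scatter) and a 1.0-fold higher number from compound 2 to compound 3 (0.02 log units; within the scatter), none beyond the scatter. Among the compounds with values here, no measured step removes the ring itself, so there is no direct guide; the insensitivity seen so far argues for a modest shift, while removal of a whole ring is a larger change and a higher number is the more likely direction. Compound 4 is therefore expected to give about 6500 nM (range 2500 nM to 18000 nM) in this assay. The expected step is a 1.5-fold higher number from compound 3 to compound 4 (0.19 log units; within the scatter).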

Compound 4, half-maximal inhibitory concentration: > 20000 nM
Compound 4: no number, only a limit; the forecaster's own chance of this, stated with the estimate: 10%; middle value at least 3.0-fold (0.48 log units) from the limit.
By their numbers in this assay, from the lowest: compounds 1, 2 and 3 (each within the scatter of the next). At a limit, above all of these: compound 4.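

Compounds 1, 2 and 3 showed only that the substituent on this ring moves the number no further than the scatter; removing the whole ring has a far larger effect. Replacing 4-fluorophenyl with hydrogen gives an at least 4.7-fold higher number from compound 3 to compound 4 (0.67 log units; beyond the scatter), while the corresponding replacements give an at least 4.9-fold higher number from compound 2 to compound 4 (0.69 log units; beyond the scatter) and an at least 7.6-fold higher number from compound 1 to compound 4 (0.88 log units; beyond the scatter). Compound 4 has a limit and not a number: the limit of > 20000 nM in this assay, at which 1 of the 4 values shown sits.

Going by these compounds, how far compound 4 lies past its limit stays open, and with it the full size of these steps. Also open, on these data alone, is whether a longer alkyl chain or a cyclohexylmethyl group on the amine nitrogen could stand in for the benzyl arm.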